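The source may report more compounds than this note shows. Statements on the series, on what has been measured and on what is new or still open speak of the compounds shown alone.

Compound 1, `O=C1O/C(=C\Cn2cc(-c3cc(F)cc(F)c3)nn2)C(OCc2ccccc2)=C1OCc1ccccc1`: in a functional assay on HepG2 cells (Homo sapiens) for antiproliferative activity, read by MTT assay, with a stated time of 72 h (a lower number here means a stronger inhibitor, a higher number a weaker inhibitor), compound 1 gives > 100000 nM, which is a limit of the assay rather than a number.
Compound 2, `COc1ccc(-c2cn(C/C=C3\OC(=O)C(OCc4ccccc4)=C3OCc3ccccc3)nn2)cc1`: in this assay compound 2 gives > 100000 nM, again a limit.
Compound 3, `COc1ccccc1-c1cn(C/C=C2\OC(=O)C(OCc3ccccc3)=C2OCc2ccccc2)nn1`: in this assay compound 3 gives > 100000 nM, also a limit.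

All three measured compounds share one core and differ only in the group on an aromatic carbon of the five-membered aromatic ring with 3 nitrogen. Because every value sits at the limit of > 100000 nM in this assay, at which 3 of the 3 values shown sit, none of the steps between them can be read: a step that the two limits leave unreadable from compound 1 to compound 2, a step that the two limits leave unreadable from compound 1 to compound 3 and a step that the two limits leave unreadable from compound 2 to compound 3 each compare two limits. Compound 3 therefore stands at the limit, with nothing in the numbers to separate it from compound 1 or compound 2.

Compound 4, `O=C1O/C(=C\Cn2cc(-c3cccc(O)c3)nn2)C(OCc2ccccc2)=C1OCc1ccccc1`, has not been measured. It differs from compound 3 in one place: 3-hydroxyphenyl in place of 2-methoxyphenyl on an aromatic carbon. For the measured compounds named here, the measured steps that bear on this change are the three just named, and each is unreadable; they show only that swapping one aryl group for another has so far not brought any compound into the measurable range of this assay. For compound 4 the expected step that the limit leaves unreadable from compound 3 to compound 4 can be given no direction from them, and the expectation is that it stays at or near the limit. Compound 4 is estimated at 150000 nM, with a range from 20000 nM to 1000000 nM, most likely reported again as a limit.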

Compound 4, half-maximal inhibitory concentration: 61700 nM
Compound 4: middle estimate off by 2.4-fold (0.39 log units), on the high side; low and high end bracket the measured number.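

In this assay compound 4, with 3-hydroxyphenyl on the aromatic carbon of the five-membered ring, is the first compound shown to give a number instead of a limit, 61700 nM, so a change of aryl group at this position can bring this series into the readable range. Set against the other three compounds, the result reads as an at least 1.6-fold lower number from compound 3 to compound 4 (0.20 log units; that floor lies within the scatter), an at least 1.6-fold lower number from compound 2 to compound 4 (0.20 log units; that floor lies within the scatter) and an at least 1.6-fold lower number from compound 1 to compound 4 (0.20 log units; that floor lies within the scatter). These are floors and not measured sizes, because the partner in each pair sits at a limit: the limit of > 100000 nM in this assay, at which 3 of the 4 values shown sit.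

Going by these compounds, what remains open is whether the readable number belongs to the hydroxyl group itself or to where it sits on the phenyl ring, a question that a 3-methoxyphenyl group at the same carbon would help to settle. On these data alone, it is also open whether other groups on the phenyl ring, such as an amine in 3-aminophenyl or a carboxylic acid, would give a number in this assay, and how far such a number would lie from the limit.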